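Lengthening the Amide Chain: From tert-Butyl to Hexyl

The source may report more compounds than this note shows. Statements on the series, on what has been measured and on what is new or still open speak of the compounds shown alone.

Of the compounds shown here, three on one shared core have been tested in a functional assay on the whole organism (strain Swiss albino) for inhibition, with Mus musculus as the target, in the writhing test, with stated times of 60 min and 15 min, at a dose of 100 mg/kg by the oral route; a lower number here means less inhibition, a higher number more inhibition at the dose given (going by the name of the read-out). Compound 1 `CCCNC(=O)CC1CCc2cc(OC)c(OC)cc21` gives 26.9%, compound 2 `CCCCNC(=O)CC1CCc2cc(OC)c(OC)cc21` gives 39.4%, and compound 3 `COc1cc2c(cc1OC)C(CC(=O)NC(C)(C)C)CC2` gives 41.8%. Compound 3 stands highest of the three, though its separation from compound 2 lies within the scatter and only its separation from compound 1 is beyond it. Compound 4 `CCCCCCNC(=O)CC1CCc2cc(OC)c(OC)cc21` differs from compound 3 in one place: hexyl in place of tert-butyl on an amide-type nitrogen. For the measured compounds named here, two measured steps bear on this, a number 14.9 percentage points higher from compound 1 to compound 3 (beyond the scatter) and a number 2.4 percentage points higher from compound 2 to compound 3 (within the scatter), while the chain-lengthening step a number 12.5 percentage points higher from compound 1 to compound 2 (beyond the scatter) shows a longer chain need not hurt. Because a number 2.4 percentage points higher from compound 2 to compound 3 (within the scatter) lies within the scatter, a step of about a number 0.2 percentage points higher from compound 3 to compound 4 (within the scatter) in this assay is expected. Compound 4 is therefore estimated at 42%, between 26% and 58%.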

Compound 4, a percentage reported as inhibition, in the whole organism at one dose (the size of the read-out at that dose, not a potency): 82.2%
Compound 4: the middle estimate sits 40.2 percentage points below what was measured, and the stated range ends below it.
By their numbers in this assay, from the lowest: compound 1; then compounds 2 and 3 (each within the scatter of the next); then compound 4.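

Hexyl on the amide-type nitrogen stands apart from the other groups at this position in this assay (with a number 40.4 percentage points higher from compound 3 to compound 4 (beyond the scatter); with a number 42.8 percentage points higher from compound 2 to compound 4 (beyond the scatter); with a number 55.3 percentage points higher from compound 1 to compound 4 (beyond the scatter)). The earlier compounds showed only a modest gain, while this change shows that the number keeps rising past butyl, with propyl, butyl and hexyl in rising order and no straight chain shown going against it. No measurement on hand explains this jump.

On these data alone, whether an octyl chain would raise the number further or lower it stays open. So does the effect of a chain ending in an amine or a carboxylic acid.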